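This account rests on a few compounds, and the source may have more. Where it says the series, first, only, none or still open, it means among the compounds named here.

In an ADME assay on A549 cells (Homo sapiens) for cytotoxicity, read by resazurin assay, with a stated time of 48 h (a lower number here means that less compound is tolerated, a higher number that more compound is tolerated), three compounds with a shared core have been examined so far. For compound 1 `CC(=O)Nc1ccc(NC(=O)c2cc(Cl)ccc2O)c(Cl)c1` the entry reads "not determined" (no result reported) and offers no number to compare. Compound 2 `CCCCCCC(C)Nc1ccc(NC(=O)c2cc(Cl)ccc2O)c(Cl)c1` gives 23500 nM and compound 3 `O=C(Nc1ccc(NCc2cc(F)cc(Cl)c2)cc1Cl)c1cc(Cl)ccc1O` gives 11100 nM as the lower of the two numbers available. Compound 4 `O=C(Nc1ccc(NCc2cc(F)cc(C(F)(F)F)c2)cc1Cl)c1cc(Cl)ccc1O` departs from compound 3 in one place, with trifluoromethyl in place of chloro on an aromatic carbon. Going by the values given here, only one measured step is available, and it bears on this change indirectly: a 2.1-fold lower number from compound 2 to compound 3 (0.33 log units; beyond the scatter) came from replacing 1-methylheptyl with 3-chloro-5-fluorobenzyl on a nitrogen on an aromatic ring. Among the compounds with values here, no measured pair tests trifluoromethyl against chloro. That modest step concerned a far larger exchange, so a smaller one is expected here, slightly toward a lower number and within the scatter. The estimated step is a 1.2-fold lower number from compound 3 to compound 4 (0.09 log units; within the scatter) in this reading. For compound 4 the expected value is 9000 nM, with an estimated range from 4500 nM to 18000 nM.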

Compound 4, half-maximal cytotoxic concentration: 30900 nM
Estimate against measurement, compound 4: 3.4-fold (0.54 log units) below; measured number outside the range, above it.
By their numbers in this assay, from the lowest: compound 3; then compounds 2 and 4 (each within the scatter of the next).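

At this aromatic carbon, meta to a fluoro group, trifluoromethyl in place of chloro gives a 2.8-fold higher number from compound 3 to compound 4 (0.44 log units; beyond the scatter) in this assay. Going by these compounds alone, the earlier step concerned the group on the nitrogen, so this is the first sign that the number also responds to a single substituent on the aromatic ring, and here the change goes toward more compound being tolerated. Nothing available accounts for this shift.

The compounds shown place only chloro and trifluoromethyl at this carbon, so it remains open how a methyl, a methoxy or a nitrile there would read and whether the number tracks the size of the group at all. Also open, from the compounds shown here alone, is whether the same exchange would move the number in the same direction with a chain such as 1-methylheptyl on the nitrogen.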